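Adding a methoxy group to a scaffold without measured potency

The source may report more compounds than this note shows. Statements on the series, on what has been measured and on what is new or still open speak of the compounds shown alone.

Of the compounds shown here, three built on one shared core have been tested in a functional assay on PC-3 cells (Homo sapiens) for antiproliferative activity, read by MTT assay, with a stated time of 48 h; a higher number here means a weaker inhibitor, a lower number a stronger inhibitor. Compound 1 `NS(=O)(=O)c1ccc(Nc2ncc(F)c(Nc3nc4ccccc4s3)n2)cc1` gives > 50000 nM, which is a limit of the assay rather than a number. Compound 2 `Cc1cnc(Nc2ccc(S(N)(=O)=O)cc2)nc1Nc1nc2ccccc2s1` gives > 50000 nM in this assay, again only a limit. Compound 3 `Cc1cnc(Nc2ccc(F)cc2)nc1Nc1nc2ccccc2s1` gives > 50000 nM in this assay, also a limit. The change from compound 1 to compound 2 is methyl in place of fluoro on an aromatic carbon, with a step that the two limits leave unreadable from compound 1 to compound 2; the change from compound 2 to compound 3 is fluoro in place of sulfamoyl on an aromatic carbon, with a step that the two limits leave unreadable from compound 2 to compound 3. Compound 2 thus stands at the limit, and so do the other two values.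

Compound 4 `COc1ccc2nc(Nc3nc(Nc4ccc(S(N)(=O)=O)cc4)ncc3C)sc2c1` differs from compound 2 in a single place: methoxy in place of hydrogen on an aromatic carbon. No size can be read from either measured step, because the limit of > 50000 nM in this assay, at which 3 of the 3 values shown sit, holds every value shown. Compound 4 is therefore expected to give 50000 nM in this assay, within a range from 15000 nM to 100000 nM, most likely again reported as a limit. The expected step from compound 2 to compound 4 is estimated as a number no higher from compound 2 to compound 4 (the limit leaves the size open).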

Compound 4, half-maximal inhibitory concentration: > 50000 nM
Compound 4 ended at the assay's limit; the forecaster's own chance of this, stated with the estimate: 85%; the middle value lies on the limit itself.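

Compound 4 gives > 50000 nM, which is a limit of the assay and not a number. No step can be read between compound 2 and compound 4, since all the values share one limit: the limit of > 50000 nM in this assay, at which 4 of the 4 values shown sit. The compounds shown leave open how strongly any of them acts, and so whether methoxy in place of hydrogen changes potency at all.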